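Methoxy for Trifluoromethyl on Two Related Cores

The source may hold more compounds than are shown below. What is called first, only, known or untested is meant among the compounds shown, and "the series" means these compounds.

Compound 1, `O=C1C(Nc2ccc(C(F)(F)F)cc2)=CC(=O)c2c1nc1n2[C@H]2OC[C@@H](O)[C@H]2OC1`, gives 2250 nM in a functional assay on ECa-109 cells for inhibition, with ECa-109 cell line (Homo sapiens) as the target, read by sulforhodamine B assay; on this read-out lower numbers stand for stronger inhibition and higher numbers for weaker inhibition.
Compound 2, `COc1ccc(NC2=CC(=O)c3c(nc4n3[C@H]3OC[C@@H](O)[C@H]3OC4)C2=O)cc1`, gives 3410 nM in this assay.
Compound 3, `O=C1C=C(Nc2ccc(C(F)(F)F)cc2)C(=O)c2c1nc1n2[C@H]2OC[C@@H](O)[C@H]2OC1`, gives 5500 nM in this assay.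

Compound 1 and compound 2 share one core and differ only in methoxy in place of trifluoromethyl on an aromatic carbon. That change gave a 1.5-fold higher number from compound 1 to compound 2 (0.18 log units; within the scatter), so the two numbers cannot be told apart. Compound 3 carries the same atoms as compound 1 joined differently; the difference between the two cores is not broken down here. Its number is the highest of the three, beyond the scatter against compound 1 but within the scatter against compound 2.

Compound 4, `COc1ccc(NC2=CC(=O)c3nc4n(c3C2=O)[C@H]2OC[C@@H](O)[C@H]2OC4)cc1`, is compound 3 with methoxy in place of trifluoromethyl on an aromatic carbon, the same change already seen, in the same place. Because compound 1 to compound 2 gave a 1.5-fold higher number from compound 1 to compound 2 (0.18 log units; within the scatter), compound 4 is expected to show a similarly small step, a 1.5-fold higher number from compound 3 to compound 4 (0.16 log units; within the scatter). On that basis compound 4 is estimated at 8000 nM in this assay, likely between 3500 nM and 18000 nM.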

Compound 4, half-maximal inhibitory concentration: > 4000 nM
Compound 4: only a limit was reported; the forecaster's own chance of this, stated with the estimate: 10%; the middle value lies beyond the limit too.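

For compound 4, this assay gives only a limit, > 4000 nM, and not a number. The step from compound 3 to compound 4 therefore cannot be read. The compounds shown leave open whether methoxy in place of trifluoromethyl does the same on the core of compound 3 as on the core of compound 1.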